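A few compounds are considered here, and "the series" means these few. Any claim that something is new, unique, unknown or untested is made for them only; others in the source may bear on it.

Compound 1, `CC(C)c1cccc(C(C)C)c1NC(=O)NCC1(c2ccc(Cl)cc2)CCCC1`, gives 32 nM in an assay on microsomes for inhibition of acyl-CoA:cholesterol acyltransferase (Oryctolagus cuniculus); on this read-out lower numbers stand for stronger inhibition and higher numbers for weaker inhibition.
Compound 2, `COc1ccc(C2(CNC(=O)Nc3c(C(C)C)cccc3C(C)C)CCCC2)cc1`, gives 31 nM in this assay.
Compound 3, `CC(C)c1cccc(C(C)C)c1NC(=O)NCC1(c2ccc(OCc3ccccc3)cc2)CCCC1`, gives 34 nM in this assay.

These three share one core and differ only in the group on the aromatic ring attached to the saturated ring carbon. Compound 2 sits alongside the other two: the steps of a 1.0-fold lower number from compound 1 to compound 2 (0.01 log units; within the scatter) and a 1.1-fold higher number from compound 2 to compound 3 (0.04 log units; within the scatter) are both within the scatter, as is a 1.1-fold higher number from compound 1 to compound 3 (0.03 log units; within the scatter), so the three numbers cannot be told apart.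

Compound 4, `CC(C)c1cccc(C(C)C)c1NC(=O)NCC1(c2cccc(C(=O)O)c2)CCCC1`, has not yet been measured. It differs from compound 2 by 3-carboxyphenyl in place of 4-methoxyphenyl on a saturated ring carbon, on a saturated ring carbon of a five-membered non-aromatic ring of carbon only. The three measured steps all swap the group on that same aromatic ring and none moved the number beyond the scatter, which hints that this ring tolerates change. None of them, however, brings in a carboxylic acid or a hydrogen-bond donor, so they only partly bear on the step to compound 4. On that basis compound 4 is expected to give about 70 nM in this assay, within 20 nM to 300 nM, a step of a 2.3-fold higher number from compound 2 to compound 4 (0.35 log units; beyond the scatter) that is estimated with low confidence.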

Compound 4, half-maximal inhibitory concentration: 620 nM
For compound 4 the middle estimate is 8.9-fold (0.95 log units) below the measured one, and the stated range ends below it.
By their numbers in this assay, from the lowest: compounds 2, 1 and 3 (each within the scatter of the next); then compound 4.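

The aromatic group on the saturated ring carbon is less forgiving than the first three compounds suggested. In this assay, 3-carboxyphenyl gives a 20-fold higher number from compound 2 to compound 4 (1.30 log units; beyond the scatter) and a 19-fold higher number from compound 1 to compound 4 (1.29 log units; beyond the scatter) while the chloro, methoxy and benzyloxy groups could not be told apart, so that tolerance holds only for those three groups and does not extend to this one. No measurement shown here accounts for this large step.

The change from 4-methoxyphenyl to 3-carboxyphenyl alters both the group and its numbered place on the aromatic ring, so the compounds shown cannot separate the effect of the carboxylic acid from that of its place. From the compounds shown here alone, a 4-carboxyphenyl or 3-methoxyphenyl group would pull these two apart, and how an amine or a primary amide would behave here also stays open.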